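The source may hold more compounds than are shown below. What is called first, only, known or untested is meant among the compounds shown, and "the series" means these compounds.

Measured so far in a functional assay for inhibition, with Rattus norvegicus as the target; on this read-out higher numbers stand for weaker inhibition and lower numbers for stronger inhibition:
- compound 1 `CCCCc1c(CC)c(OC(C)=O)c2ccccc2c1OC` gives 1130 nM
- compound 2 `CCCCc1cc(OC)c2c(OC)cccc2c1OC(C)=O` gives 260 nM

Compound 2 holds the lower number of the two, at 260 nM against compound 1 at 1130 nM, a gap beyond the usual scatter. Compound 3 `CCCCc1cc(OC)c2c(C)cccc2c1OC(C)=O` is not yet measured. It differs from compound 2 in one place, with methyl in place of methoxy on an aromatic carbon. Within the data shown here, no measured pair isolates this change, and compound 1 differs from compound 2 in more than one place, so the direction rests on judgement alone. In this assay a modest move toward weaker inhibition is expected, which may not clear the scatter. The expected step is a 1.7-fold higher number from compound 2 to compound 3 (0.24 log units; within the scatter) in this estimate. For compound 3 the estimated value is 450 nM with an expected range from 130 nM to 1500 nM in this assay.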

Compound 3, half-maximal inhibitory concentration: 620 nM
Compound 3: the middle estimate sits 1.4-fold (0.14 log units) below what was measured; low and high end bracket the measured number.
By their numbers in this assay, from the lowest: compound 2; then compounds 3 and 1 (each within the scatter of the next).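

In this assay, among these compounds, the change of methyl in place of methoxy on an aromatic carbon gives the first single-place reading at this position, with a 2.4-fold higher number from compound 2 to compound 3 (0.38 log units; beyond the scatter) as a modest step beyond the scatter. The methoxy at this carbon, ortho to a fused ring and meta to a fused ring, is therefore not interchangeable with methyl here, and the methoxy holds the lower number. Nothing shown bears on the reason for this step.

From the compounds shown here alone, with only methoxy and methyl seen at this position, it remains open whether a hydroxyl, a chlorine atom, an amine or a longer ethoxy chain would fall nearer compound 2 or compound 3. Going by these compounds, whether the step carries over to the core of compound 1 also remains open.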